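From Bromophenyl to Dichlorophenyl in a Cytotoxicity Series

The compounds below may be only part of what the source reports. "The series", "measured", "known", "first", "only" and "open" are said of these compounds alone.

Among the measured compounds shown here, in a functional assay on HCT-116 cells (Homo sapiens) for cytotoxicity, read by cell counting, with a stated time of 48 h (on this read-out lower numbers stand for stronger inhibition and higher numbers for weaker inhibition), compound 2 `Clc1cccc(Nc2ncc3cccc(OCc4cn(-c5ccc(Br)cc5)nn4)c3n2)c1` gives 17000 nM, the only exact number so far. Compound 1 `Cc1ccc(-n2cc(COc3cccc4cnc(Nc5cccc(Cl)c5)nc34)nn2)c([N+](=O)[O-])c1` reads > 25000 nM, which is a limit of the assay and not a number. For the measured compounds named here, the one measured step is an at least 1.4-fold lower number from compound 1 to compound 2 (0.16 log units; that floor lies within the scatter), and it places 4-bromophenyl in place of 4-methyl-2-nitrophenyl on an aromatic nitrogen. Going by these compounds, its full size stays open because of the limit of > 25000 nM in this assay, at which 1 of the 2 values shown sits.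

Compound 3 `Clc1cccc(Nc2ncc3cccc(OCc4cn(-c5cc(Cl)cc(Cl)c5)nn4)c3n2)c1` changes that same aromatic nitrogen substituent, with 3,5-dichlorophenyl in place of 4-bromophenyl on an aromatic nitrogen. Going by the values given here, the single step measured at this place shows no change beyond the scatter, so the new group is not expected to shift this assay clearly in either direction. The expected change is a 1.1-fold lower number from compound 2 to compound 3 (0.05 log units; within the scatter). For compound 3 the estimated value is 15000 nM, with an expected range of 6000 nM to 32000 nM.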

Compound 3, half-maximal inhibitory concentration: 8000 nM
Compound 3: the middle estimate sits 1.9-fold (0.27 log units) above what was measured, within the range that was stated.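

In this assay, this aromatic nitrogen substituent now gives a step beyond the scatter: with 3,5-dichlorophenyl in place of 4-bromophenyl, there is a 2.1-fold lower number from compound 2 to compound 3 (0.33 log units; beyond the scatter). Replacing 4-methyl-2-nitrophenyl with 3,5-dichlorophenyl gives an at least 3.1-fold lower number from compound 1 to compound 3 (0.49 log units; beyond the scatter), so even the floor of this comparison now clears the scatter, which the floor of the earlier step from that group did not do. Compound 1 reads a limit and not a number, so the full size of that step stays unknown: the limit of > 25000 nM in this assay, at which 1 of the 3 values shown sits.

The step from compound 2 changes the halogen, the number of halogens and their places on the phenyl ring all at once, so these compounds cannot show which of these matters. Going by these compounds, how a 4-chlorophenyl, a 3,5-dibromophenyl or a phenyl ring carrying an amine or a carboxylic acid would read at this position also remains open.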